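Swapping the Benzyl Group on the Core for Pentan-3-yl

This account rests on a few compounds, and the source may have more. Where it says the series, first, only, none or still open, it means among the compounds named here.

Compound 1 `COc1ccc(F)cc1CNCCCNc1ccnc2cc(Cc3cc(C)cc(C)c3)ccc12` is measured in an ADME assay for permeability, using PAMPA, with a stated time of 30 min, at pH 7.4 (a lower number here means that the compound crosses the layer more slowly, a higher number that the compound crosses the layer faster), where compound 1 gives 23 10^-6 cm/s. Compound 2 `Cc1cc(C)cc(Cc2ccc3c(NCCCNCc4ccco4)ccnc3c2)c1` gives 23 10^-6 cm/s, and the step of no change at the digits printed from compound 1 to compound 2 (within the scatter) is within the scatter, so compound 1 and compound 2 sit together at the lowest of the three numbers. Among the measured compounds shown here, compound 3 `COc1cccc(CNCCCNc2ccnc3cc(-c4ccccc4)ccc23)c1O` gives 237 10^-6 cm/s, a value that stands well above that of compound 1, but compound 3 differs from compound 1 in two places, so no single step connects them.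

Compound 4 `CCC(CC)c1ccc2c(NCCCNCc3cc(F)ccc3OC)ccnc2c1` differs from compound 1 in one place: pentan-3-yl in place of 3,5-dimethylbenzyl on an aromatic carbon. For the measured compounds named here, no measured step changes this part of the core, so no direct guide exists; the one measured step, no change at the digits printed from compound 1 to compound 2 (within the scatter), alters the other end of the chain and does not bear on it. A modest shift at most is therefore expected, without a sure direction, giving an estimated step of a 1.5-fold higher number from compound 1 to compound 4 (0.18 log units; within the scatter). Compound 4 is expected to give 35 10^-6 cm/s, with a likely range from 12 10^-6 cm/s to 100 10^-6 cm/s.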

Compound 4, apparent permeability: 23 10^-6 cm/s
Compound 4: the middle estimate sits 1.5-fold (0.18 log units) above what was measured; low and high end bracket the measured number.
By their numbers in this assay, from the lowest: compounds 1, 2 and 4 (each within the scatter of the next); then compound 3.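

In this assay, pentan-3-yl in place of 3,5-dimethylbenzyl gives no change at the digits printed from compound 1 to compound 4 (within the scatter), so the number holds when this position on the core loses its aromatic ring and goes from 9 heavy atoms to 5. Among the compounds shown here, the earlier step changed only the other end of the chain, so this is the first reading at this position. Nothing measured here offers a reason for this result. Still open, as far as these compounds go, is whether an amine or a carboxylic acid at this position would move the number, and whether a group with no ring gives the same reading alongside furan-2-yl.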